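Swapping iodo for nitro on a potent series

The compounds below may be only part of what the source reports. "The series", "measured", "known", "first", "only" and "open" are said of these compounds alone.

Compound 1 `C/C(=N/NC(=S)Nc1ccccc1F)c1ccccn1` gives 5 nM
Compound 2 `CC(=NNC(=S)Nc1ccccc1[N+](=O)[O-])c1ccccn1` gives 4.3 nM
Compound 3 `C/C(=N/NC(=S)Nc1ccccc1I)c1ccccn1` gives 6.1 nM

In a functional assay on U-87MG ATCC cells (Homo sapiens) for cytotoxicity, read by MTT assay, with a stated time of 48 h (on this read-out higher numbers stand for weaker inhibition and lower numbers for stronger inhibition), compound 3 gives 6.1 nM and so lies within the scatter of the other two compounds. Scatter here means the spread expected when the same measurement is repeated, so these three values cannot be ranked.

The next compound to be tested is compound 4 `C/C(=N/NC(=S)Nc1ccccc1[N+](=O)[O-])c1ccccn1`. It has nitro in place of iodo on an aromatic carbon, at a place on a six-membered aromatic ring of carbon only, ortho to a large group (nitro in place of iodo on an aromatic carbon).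

Two observations bear on this change. Going by the values given here, the one measured step at this place, iodo in place of fluoro, gave a 1.2-fold higher number from compound 1 to compound 3 (0.09 log units; within the scatter) and stayed within the scatter. Compound 2 also carries nitro at this place and gives 4.3 nM within the scatter of compound 3. Swapping groups here has so far made no clear difference in this assay, so no shift beyond the scatter is expected in either direction.

The expected change is small, namely a 1.3-fold lower number from compound 3 to compound 4 (0.12 log units; within the scatter) and no more than the scatter allows. Compound 4 is therefore estimated at 4.6 nM (expected range 2.5 nM to 8.5 nM).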

Compound 4, half-maximal inhibitory concentration: 4.3 nM
For compound 4 the middle estimate is 1.1-fold (0.03 log units) above the measured one; the range from low to high includes it.
By their numbers in this assay, from the lowest: compounds 2, 4, 1 and 3 (each within the scatter of the next).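

Nitro in place of iodo gives a 1.4-fold lower number from compound 3 to compound 4 (0.15 log units; within the scatter), and nitro in place of fluoro gives a 1.2-fold lower number from compound 1 to compound 4 (0.07 log units; within the scatter), so in this assay iodo, fluoro and nitro at this place on the aromatic ring now all lie within the scatter of one another. The swap from iodo to nitro is not a minor edit on paper, since it replaces 1 heavy atom with 3 and 0 hydrogen-bond acceptors with 2, yet the read-out shows no clear response to it. The last pair has the same atoms and bonds and shows no change at the digits printed from compound 2 to compound 4 (within the scatter), so it says nothing about changing a group, and all that separates the two structures is how they are drawn: the fact that one of compounds 2 and 4 is drawn with a defined configuration and the other without, at the place where they differ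

The compounds shown cover only these three groups at this place, so it remains open whether a methoxy group, an amine or a carboxylic acid there would move the number beyond the scatter. On these data alone, it also remains open whether a change elsewhere on the shared core would matter more than any swap at this place.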